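A Chloro Substitution Carried From One Core to Another

This account rests on a few compounds, and the source may have more. Where it says the series, first, only, none or still open, it means among the compounds named here.

Compound 1 `O=S(=O)(/C=C/c1ccccn1)c1ccc(Cl)cc1` gives in an assay on U2OS cells for activation of nuclear factor erythroid 2-related factor 2 (Homo sapiens), read by beta-arrestin recruitment, with a stated time of 6 h (a lower number here means that less compound is needed, a higher number that more compound is needed for the effect), a value of 1730 nM. Compound 2 `O=S(=O)(/C=C/c1cccc(Cl)n1)c1ccc(Cl)cc1` differs from compound 1 by chloro in place of hydrogen on an aromatic carbon, and in this assay compound 2 gives 1460 nM, so that the step is a 1.2-fold lower number from compound 1 to compound 2 (0.07 log units; within the scatter). Compound 3 `O=S(=O)(/C=C/c1cccnc1)c1ccccc1Cl` is built from the same atoms joined differently; the difference between the two cores is not broken down here. In this assay compound 3 gives 2850 nM, and its gaps to compound 1 and to compound 2 both fall within the scatter. Compound 4 `O=S(=O)(/C=C/c1ccc(Cl)nc1)c1ccccc1Cl` has not yet been measured; it differs from compound 3 by chloro in place of hydrogen on an aromatic carbon, the same kind of change as before, though here the chloro sits para to a large group rather than meta to a large group. Because the earlier step was a 1.2-fold lower number from compound 1 to compound 2 (0.07 log units; within the scatter), compound 4 is expected to show a step of a 1.2-fold lower number from compound 3 to compound 4 (0.07 log units; within the scatter), an estimated value of about 2400 nM with a range from 1200 nM to 4800 nM.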

Compound 4, half-maximal effective concentration: 1630 nM
For compound 4 the middle estimate is 1.5-fold (0.17 log units) above the measured one; measured number inside the range.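

In this assay, chloro in place of hydrogen on an aromatic carbon gives a 1.7-fold lower number from compound 3 to compound 4 (0.24 log units; within the scatter). Set beside the same change on the core of compound 1, the step carries over without a difference that can be told from the scatter: the same change on two cores in this assay, a 1.2-fold lower number (0.07 log units; within the scatter) from compound 1 to compound 2 and a 1.7-fold lower number (0.24 log units; within the scatter) from compound 3 to compound 4, 1.5-fold (0.17 log units) apart, within the scatter of two such steps. Within the data shown here, this shows only that the two steps agree and that both are small; it does not show that chloro lowers the number on either core, and two pairs say nothing about any further core.

The compounds shown leave open whether another group in place of the chloro, such as an amine, a nitrile or a carboxylic acid, would give a step beyond the scatter. They also leave open what a longer chain there would do.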